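The compounds below may be only part of what the source reports. "The series", "measured", "known", "first", "only" and "open" are said of these compounds alone.

Working notes on the cap of a peptidic series in an assay on isolated protein for displacement of a labelled ligand from Chromobox protein homolog 7 (Homo sapiens), read by fluorescence polarization, with a stated time of 15 min; on this read-out lower numbers stand for stronger inhibition and higher numbers for weaker inhibition. Compound 1 `CC(C)C[C@H](NC(=O)[C@H](C)NC(=O)CNC(=O)c1ccccc1)C(=O)N[C@@H](CCCC[N+](C)(C)C)C(=O)N[C@@H](CO)C(N)=O` gives 58000 nM in this assay. Compound 2 `COc1ccc(S(=O)(=O)N[C@@H](C)C(=O)N[C@@H](CC(C)C)C(=O)N[C@@H](CCCC[N+](C)(C)C)C(=O)N[C@@H](CO)C(N)=O)cc1` returns only a limit of this assay, > 250000 nM. The step of an at least 4.3-fold higher number from compound 1 to compound 2 (0.63 log units; beyond the scatter) is therefore known only as a lower bound, because of the limit of > 250000 nM in this assay, at which 1 of the 2 values shown sits. Compound 3 `CC(C)C[C@H](NC(=O)[C@H](C)NCc1ccc(C(=O)O)cc1)C(=O)N[C@@H](CCCC[N+](C)(C)C)C(=O)N[C@@H](CO)C(N)=O` has not yet been measured in this assay. It differs from compound 2 by 4-carboxybenzyl in place of (4-methoxyphenyl)sulfonyl on an amine nitrogen. No measured step carries this exact change; the single step shown, from compound 1 to compound 2, concerns the cap on the same amine nitrogen and shows that exchanging the cap moves this assay by at least a modest amount, so a step beyond the scatter is plausible, though its direction is open. Compound 3 is expected to give 150000 nM, in the range 40000 nM to 500000 nM, an expected step of an at least 1.6-fold lower number from compound 2 to compound 3 (0.22 log units; that floor lies within the scatter), with a fair chance that only a limit is reported again.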

Compound 3, half-maximal inhibitory concentration: > 2000000 nM
Compound 3 gave a limit, no number; the forecaster's own chance of this, stated with the estimate: 45%; middle value at least 13-fold (1.12 log units) away from the limit.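

In this assay compound 3 gives only a limit of the assay, > 2000000 nM. Exchanging the cap on this amine nitrogen now shows a large step, an at least 34-fold higher number from compound 1 to compound 3 (1.53 log units; beyond the scatter), and neither replacement of (benzamidomethyl)carbonyl shown, in compound 2 or compound 3, gives a lower number. The step joining the two limits cannot be read, so (4-methoxyphenyl)sulfonyl and 4-carboxybenzyl remain unranked against each other.

The compounds shown do not tell which part of the (benzamidomethyl)carbonyl cap accounts for the gap to compound 1. As far as these compounds go, it also remains open whether a plain benzoyl or acetyl on this amine nitrogen, or a methyl ester in place of the carboxylic acid of 4-carboxybenzyl, would return a number rather than a limit.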